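A few compounds are considered here, and "the series" means these few. Any claim that something is new, unique, unknown or untested is made for them only; others in the source may bear on it.

Compound 1 `COc1cc(OC)c(OC)cc1/C=C/C(=O)c1ccc(C)cc1`: 81100 nM
Compound 2 `COc1cc(OC)c(-c2cc(=O)c3cc(O)ccc3o2)cc1OC`: > 150000 nM

Both compounds were tested in a functional assay on SW982 cells (Homo sapiens) for inhibition, read by MTT assay, with a stated time of 72 h; on this read-out lower numbers stand for stronger inhibition and higher numbers for weaker inhibition. In this assay, among the measured compounds shown here, compound 1 gives 81100 nM, and this is the only numerical value in the set. For compound 2 the result in this assay is a limit of the assay, > 150000 nM, which is the limit of > 150000 nM in this assay, at which 1 of the 2 values shown sits. For the measured compounds named here, compound 1 therefore stands as the single compound with a measured number, the other value sitting at the limit. Going by the values given here, no two measured compounds differ in only one place, so no measured step is available to calibrate a change.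

Compound 3 `COc1cc(OC)c(OC)cc1/C=C/C(=O)c1ccc(O)cc1O` has not yet been measured. It derives from compound 1 through one exchange: 2,4-dihydroxyphenyl in place of 4-methylphenyl on a carbonyl carbon. Among the compounds with values here, with no measured step of this kind among the compounds, the direction and size of the change can only be estimated. A modest gain, somewhat beyond the usual scatter, is expected, and the step of a 2.3-fold lower number from compound 1 to compound 3 (0.36 log units; beyond the scatter) reflects that expectation. For compound 3 the expected value in this assay is 35000 nM, with a range from 9000 nM to 150000 nM.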

Compound 3, half-maximal inhibitory concentration: 32400 nM
The estimate for compound 3 lay 1.1-fold (0.03 log units) above the measured number, within the range that was stated.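

In this assay, among the compounds shown here, the exchange of 4-methylphenyl for 2,4-dihydroxyphenyl on the carbonyl carbon gives the first measured step in the set, a 2.5-fold lower number from compound 1 to compound 3 (0.40 log units; beyond the scatter), and so shows that the group at this place on the core of compound 1 can change the read-out. The step is modest but lies beyond the usual scatter, and the entering group differs from the leaving one in carrying hydrogen-bond donors and acceptors, although this single exchange cannot show which of its features accounts for the step. Compound 2 offers no step to either of the other compounds, and its result is a limit of the assay: the limit of > 150000 nM in this assay, at which 1 of the 3 values shown sits.

The compounds shown leave open whether both hydroxyl groups of the 2,4-dihydroxyphenyl are needed for the lower number, or whether a phenyl ring carrying a single hydroxyl group would give the same result. Going by these compounds, it also remains open how an amine or a carboxylic acid on that ring would compare at this place on the shared core.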